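The source may hold more compounds than are shown below. What is called first, only, known or untested is meant among the compounds shown, and "the series" means these compounds.

Working notes on the series. For the measured compounds named here, in a physicochemical assay for solubility, at pH 7.4 (on this read-out lower numbers stand for lower solubility and higher numbers for higher solubility), compound 1 `O=C(/C=C/c1ccc(/C=C/C(=O)c2ccccc2)cn1)NO` gives 27000 nM, the lowest number so far, while compound 2 `CN1CCN(c2ccccc2C(=O)/C=C/c2ccc(/C=C/C(=O)NO)nc2)CC1` gives 469000 nM and compound 3 `CN1CCN(c2cccc(C(=O)/C=C/c3ccc(/C=C/C(=O)NO)nc3)c2)CC1` gives 104000 nM. Compound 4 `CN1CCN(c2ccc(C(=O)/C=C/c3ccc(/C=C/C(=O)NO)nc3)cc2)CC1` remains unmeasured. Relative to compound 1, it carries 4-methylpiperazin-1-yl in place of hydrogen on an aromatic carbon, para to a large group: 4-methylpiperazin-1-yl in place of hydrogen on an aromatic carbon. Two measured steps make the same exchange at other places: a 17-fold higher number from compound 1 to compound 2 (1.24 log units; beyond the scatter), which is large, and a 3.9-fold higher number from compound 1 to compound 3 (0.59 log units; beyond the scatter), which is modest. Both go upward, so a modest to large rise is expected in this assay. The expected step is a 4.8-fold higher number from compound 1 to compound 4 (0.68 log units; beyond the scatter). For compound 4 the estimated value is 130000 nM, with an expected range of 45000 nM to 400000 nM.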

Compound 4, solubility: 29000 nM
For compound 4 the middle estimate is 4.5-fold (0.65 log units) above the measured one, and the stated range ends above it.
By their numbers in this assay, from the lowest: compounds 1 and 4 (each within the scatter of the next); then compound 3; then compound 2.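

In this assay, 4-methylpiperazin-1-yl in place of hydrogen on an aromatic carbon, para to a large group, gives a 1.1-fold higher number from compound 1 to compound 4 (0.03 log units; within the scatter) and so shows that this exchange does not raise the number at every place on the ring. The same exchange at the other two places gives a 17-fold higher number from compound 1 to compound 2 (1.24 log units; beyond the scatter) and a 3.9-fold higher number from compound 1 to compound 3 (0.59 log units; beyond the scatter) so, across these compounds, the outcome varies with place. No available data bear on the reason for this difference. From the compounds shown here alone, whether a smaller group at this place, such as dimethylamino or morpholin-4-yl, would also leave the number within the scatter of compound 1 remains open.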